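A few compounds are considered here, and "the series" means these few. Any claim that something is new, unique, unknown or untested is made for them only; others in the source may bear on it.

Compound 1 `COc1cc2c(Oc3ccc(NC(=O)c4cc(-c5ccccc5)ccn4)cc3F)ccnc2cc1OCCCN1CCCC1` in a functional assay on HT-29 cells (Homo sapiens) for cytotoxicity, read by MTT assay, with a stated time of 72 h (a higher number here means a weaker inhibitor, a lower number a stronger inhibitor), gives 120 nM. Compound 2 `COc1cc2c(Oc3ccc(NC(=O)c4cc(-c5ccccc5C)ccn4)cc3F)ccnc2cc1OCCCN1CCCC1` differs from it by methyl in place of hydrogen on an aromatic carbon and gives 1150 nM, so the step of a 9.6-fold higher number from compound 1 to compound 2 (0.98 log units; beyond the scatter). Compound 3 `COc1cc2c(Oc3ccc(NC(=O)c4nccc(-c5ccccc5)n4)cc3F)ccnc2cc1OCCCN1CCCC1` differs from compound 1 by 4-phenylpyrimidin-2-yl in place of 4-phenylpyridin-2-yl on a carbonyl carbon, and compound 3 gives 390 nM, the step being a 3.3-fold higher number from compound 1 to compound 3 (0.51 log units; beyond the scatter). Compound 4 `COc1cc2c(Oc3ccc(NC(=O)c4nccc(-c5ccc(C)cc5)n4)cc3F)ccnc2cc1OCCCN1CCCC1` has not been measured; it differs from compound 3 by methyl in place of hydrogen on an aromatic carbon. This is the same kind of change as that from compound 1 to compound 2, but not the same: in compound 2 the methyl sits ortho to a large group, in compound 4 para to a large group. Within the data shown here, the only guide is that the earlier methyl produced a 9.6-fold higher number from compound 1 to compound 2 (0.98 log units; beyond the scatter). Because that earlier step a 9.6-fold higher number from compound 1 to compound 2 (0.98 log units; beyond the scatter) came at a different place, a smaller step is expected, a 2.1-fold higher number from compound 3 to compound 4 (0.31 log units; beyond the scatter). Compound 4 is therefore expected to give 800 nM, somewhere between 300 nM and 2500 nM.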

Compound 4, half-maximal inhibitory concentration: 670 nM
Beside the measured number, compound 4's estimate is 1.2-fold (0.08 log units) above it, and the stated range covers the measured number.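

In this assay, adding a methyl to the phenyl ring of compound 3 gives a 1.7-fold higher number from compound 3 to compound 4 (0.24 log units; within the scatter), so on this core the change cannot be told apart from the usual scatter. The same change does not keep its size from one core to the other: the same change on two cores in this assay, a 9.6-fold higher number (0.98 log units; beyond the scatter) from compound 1 to compound 2 and a 1.7-fold higher number (0.24 log units; within the scatter) from compound 3 to compound 4, 5.6-fold (0.75 log units) apart, beyond the scatter of two such steps. Yet these two pairs differ in both the core and the place of the methyl, which is para to a large group in compound 4 and elsewhere on the ring in compound 2, so they do not show which of the two matters.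

Still open, going by these compounds, is what a methyl placed as in compound 2 would do on the core of compound 3. Also open, on these data alone, is how an amine or a carboxylic acid would read in place of the methyl of compound 4.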